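This account rests on a few compounds, and the source may have more. Where it says the series, first, only, none or still open, it means among the compounds named here.

Measured compounds:
compound 1, `O=C1Nc2ccccc2/C1=C\c1c(Cl)n(Cc2ccccc2)c2ccccc12`, 8910 nM
compound 2, `O=C1Nc2ccccc2/C1=C\c1c(Cl)n(CCCc2ccccc2)c2ccccc12`, 13800 nM

In a functional assay on cells (Melanoma cell, Homo sapiens) for cytotoxicity, with a stated time of 48 h (on this read-out higher numbers stand for weaker inhibition of growth and lower numbers for stronger inhibition of growth), compound 2 stands at the higher of the two numbers; its nearest neighbour is compound 1, with a 1.5-fold higher number from compound 1 to compound 2 (0.19 log units; within the scatter). Compound 3, `O=C1Nc2ccc(Cl)cc2/C1=C\c1c(Cl)n(CCCc2ccccc2)c2ccccc12`, differs from compound 2 by chloro in place of hydrogen on an aromatic carbon. For the measured compounds named here, no measured step touches that ring; the only measured step, a 1.5-fold higher number from compound 1 to compound 2 (0.19 log units; within the scatter), concerns the chain and lies within the scatter, so the data give no ground to expect a step beyond the scatter for compound 3. Compound 3 is therefore estimated at 12000 nM, with a range from 4000 nM to 36000 nM, an expected step of a 1.2-fold lower number from compound 2 to compound 3 (0.06 log units; within the scatter).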

Compound 3, concentration for 50% growth inhibition: 2040 nM
For compound 3 the middle estimate is 5.9-fold (0.77 log units) above the measured one, outside the stated range (below it).
By their numbers in this assay, from the lowest: compound 3; then compounds 1 and 2 (each within the scatter of the next).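

In this assay, for the compounds shown here, chloro in place of hydrogen on an aromatic carbon gives a 6.8-fold lower number from compound 2 to compound 3 (0.83 log units; beyond the scatter), the first step beyond the scatter. The only earlier step, a 1.5-fold higher number from compound 1 to compound 2 (0.19 log units; within the scatter), changed the chain and stayed within it, so this aromatic carbon is the first place shown where a change of one heavy atom moves growth inhibition. Nothing available explains this step. Going by these compounds, whether fluoro, methoxy or an amine on this carbon would give a similar step remains open, as does whether chloro here would do the same with the chain of compound 1.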